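A few compounds are considered here, and "the series" means these few. Any claim that something is new, unique, unknown or untested is made for them only; others in the source may bear on it.

Of the compounds shown here, three in this set have been tested in a functional assay on CRL2813 cells (Homo sapiens) for cytotoxicity, read by sulforhodamine B assay, with a stated time of 5 days (on this read-out higher numbers stand for weaker inhibition and lower numbers for stronger inhibition), and each returns only a limit of the assay rather than a number. Compound 1 `O=C(Nc1cccc(C(F)(F)F)c1)N[C@H]1CC[C@H](O)CC1` gives > 20000 nM in this assay, which is a limit. Compound 2 `O=C(Nc1ccccc1C(=O)O)N[C@H]1CC[C@@H](Oc2ccc(F)cc2)CC1` gives > 20000 nM, again a limit. Compound 3 `CSc1ccccc1NC(=O)N[C@H]1CC[C@H](Oc2ccc(F)cc2)CC1` gives > 20000 nM, also a limit, which places compound 3 at the limit of > 20000 nM in this assay, at which 3 of the 3 values shown sit, together with the other two, so no ordering among them can be read from these numbers.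

Compound 4 `COc1ccc(NC(=O)N[C@H]2CC[C@H](Oc3ccc(F)cc3)CC2)cc1` has not yet been measured. It differs from compound 3 in one place: 4-methoxyphenyl in place of 2-(methylsulfanyl)phenyl on an amide-type nitrogen. Among the measured compounds shown here, no pair of measured compounds isolates this change, so the numbers at hand say nothing about how it acts on its own. With every measured value sitting at the same limit, the expectation is that compound 4 likewise reaches no number in this assay. The step of a number no higher from compound 3 to compound 4 (the limit leaves the size open) is expected to be none beyond the scatter. Compound 4 is therefore estimated at 20000 nM, with a range from 5000 nM to 80000 nM, and most likely it will once more be reported as a limit rather than as a number.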

Compound 4, half-maximal inhibitory concentration: > 20000 nM
Compound 4: a limit, no number; the forecaster's own chance of this, stated with the estimate: 70%; the middle value lies on the limit itself.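

No step can be read from compound 3 to compound 4, because both stop at a limit rather than a number in this assay: the limit of > 20000 nM in this assay, at which 4 of the 4 values shown sit. The compounds shown leave open how 4-methoxyphenyl and 2-(methylsulfanyl)phenyl compare, and whether any change to the shared core would give a measurable number in this assay.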